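Trifluorophenyl Replaces Dichlorophenyl on a Naphthoquinone Series

The compounds below may be only part of what the source reports. "The series", "measured", "known", "first", "only" and "open" are said of these compounds alone.

Two members of this series have been measured in a functional assay on MCF7 cells (Homo sapiens) for cytotoxicity, read by MTT assay, with a stated time of 48 h; a lower number here means a stronger inhibitor, a higher number a weaker inhibitor. Compound 1 `Cc1ccc(S(=O)(=O)/N=C(/CCNC2=CC(=O)c3ccccc3C2=O)Nc2ccccc2[N+](=O)[O-])cc1` gives 3090 nM. Among the measured compounds shown here, compound 2 `Cc1ccc(S(=O)(=O)/N=C(/CCNC2=CC(=O)c3ccccc3C2=O)Nc2ccc(Cl)cc2Cl)cc1` gives 17000 nM, the highest of the two numbers, and its nearest neighbour is compound 1 at a step of a 5.5-fold higher number from compound 1 to compound 2 (0.74 log units; beyond the scatter), the only measured step available. Compound 3 `Cc1ccc(S(=O)(=O)/N=C(/CCNC2=CC(=O)c3ccccc3C2=O)Nc2cc(F)c(F)c(F)c2)cc1` has not been measured yet; it differs from compound 2 by 3,4,5-trifluorophenyl in place of 2,4-dichlorophenyl on an amine nitrogen.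

For the measured compounds named here, the one measured step bears only loosely on this change, since it swaps a halogenated phenyl for a nitrophenyl rather than one halogenated phenyl for another. Going by the values given here, a move between two halogenated aryl groups on the same amine nitrogen has no direct precedent here, so the step is expected to be small, with a slight lean toward a lower number given that compound 2 already stands at the high end. For compound 3 the expected step is a 1.4-fold lower number from compound 2 to compound 3 (0.15 log units; within the scatter), and its estimated value in this assay is 12000 nM, with a range from 4000 nM to 40000 nM.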

Compound 3, half-maximal inhibitory concentration: 6610 nM
The estimate for compound 3 lay 1.8-fold (0.26 log units) above the measured number, and the stated range covers the measured number.
By their numbers in this assay, from the lowest: compound 1; then compound 3; then compound 2.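

In this assay, the exchange of 2,4-dichlorophenyl for 3,4,5-trifluorophenyl on the amine nitrogen gives a 2.6-fold lower number from compound 2 to compound 3 (0.41 log units; beyond the scatter). This shows that the number at this place depends on which halogenated phenyl is present, something the earlier pair, a nitrophenyl against a dichlorophenyl, could not show. The trifluorophenyl group does not close the whole gap to the 2-nitrophenyl group, however, with a 2.1-fold higher number from compound 1 to compound 3 (0.33 log units; beyond the scatter), so compound 1 keeps the lowest number of the three, and no measurement shown here offers an explanation for these differences.

The step from compound 2 to compound 3 changes the kind of halogen, the number of halogens and their places on the phenyl ring all at once, so these three compounds cannot tell which of those changes accounts for the shift. Going by these compounds, it also remains open where an unsubstituted phenyl or a 4-methoxyphenyl group on the same amine nitrogen would fall relative to these three compounds in this assay.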